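A few compounds are considered here, and "the series" means these few. Any claim that something is new, unique, unknown or untested is made for them only; others in the source may bear on it.

Measured in a functional assay on KB cells (Homo sapiens) for cytotoxicity; a higher number here means that more compound is needed for the effect, a lower number that less compound is needed:
- Compound 1 `COC1=C(C)C(=O)/C(=C(O)/C=C/c2ccc(Br)cc2)C(=O)C1(C)C`: 1.7 ug/mL
- Compound 2 `COC1=C(C)C(=O)/C(=C(O)/C=C/c2ccc(F)cc2)C(=O)C1(C)C`: 3.7 ug/mL
- Compound 3 `CCc1ccc(/C=C/C(O)=C2/C(=O)C(C)=C(OC)C(C)(C)C2=O)cc1`: 6.9 ug/mL

The high end of the range is shared: a 1.9-fold higher number from compound 2 to compound 3 (0.27 log units; within the scatter), whereas a 4.1-fold higher number from compound 1 to compound 3 (0.61 log units; beyond the scatter). The next change is 3,5-dimethylphenyl in place of 4-ethylphenyl on a double-bonded chain carbon bound to a double-bonded chain carbon, which gives compound 4 `COC1=C(C)C(=O)/C(=C(O)/C=C/c2cc(C)cc(C)c2)C(=O)C1(C)C`. Among the measured compounds shown here, no measured step makes this kind of change. Each one swaps a single group on an aromatic carbon, so they bear on it only indirectly. The other step is also modest: a 2.2-fold higher number from compound 1 to compound 2 (0.34 log units; beyond the scatter). The largest of the three is a 4.1-fold higher number from compound 1 to compound 3 (0.61 log units; beyond the scatter), so no step beyond the scatter is expected in this assay. The expected change is a 1.4-fold lower number from compound 3 to compound 4 (0.14 log units; within the scatter). Compound 4 is estimated at 5 ug/mL, with an expected range of 2 ug/mL to 12 ug/mL.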

Compound 4, concentration for half-maximal effect: 3.1 ug/mL
Estimate against measurement, compound 4: 1.6-fold (0.21 log units) above; the range from low to high includes it.
By their numbers in this assay, from the lowest: compounds 1, 4, 2 and 3 (each within the scatter of the next, the first and the last beyond it).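

In this assay, 3,5-dimethylphenyl and 4-ethylphenyl have the same atoms joined differently, yet the swap gives a shift beyond the scatter (a 2.2-fold lower number from compound 3 to compound 4 (0.35 log units; beyond the scatter)). Compound 4 cannot be separated from the compounds carrying 4-fluorophenyl (a 1.2-fold lower number from compound 2 to compound 4 (0.08 log units; within the scatter)) or 4-bromophenyl (a 1.8-fold higher number from compound 1 to compound 4 (0.26 log units; within the scatter)), so this position tolerates the two-methyl arrangement within this narrow range. Nothing measured here accounts for the shift. The compounds shown leave open how an amine or a carboxylic acid on the aromatic ring would read, and whether a longer chain would follow 4-ethylphenyl.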